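From chloro to fluoro on the cytotoxicity read-out

The source may report more compounds than this note shows. Statements on the series, on what has been measured and on what is new or still open speak of the compounds shown alone.

In an ADME assay on L6 cells (Rattus norvegicus) for cytotoxicity, read by resazurin assay, with a stated time of 72 h (on this read-out lower numbers stand for stronger inhibition and higher numbers for weaker inhibition), compound 1 `OC(c1ccc(Cl)cc1)(c1cccnc1)c1ccccc1F` reports only the limit > 100000 nM as its result. Among the measured compounds shown here, compound 2 `OC(c1ccc(Cl)cc1)(c1cccnc1)c1ccc(Cl)cc1F` gives 59400 nM as the only actual number so far. Compound 3 `OC(c1ccc(Cl)cc1)(c1cccnc1)c1ccc(F)cc1F` has fluoro in place of chloro on an aromatic carbon, with fluoro in place of chloro on an aromatic carbon as the difference from compound 2. Going by an at least 1.6-fold lower number from compound 1 to compound 2 (0.22 log units; that floor lies within the scatter) as the one measured step at this place, and by the limit of > 100000 nM in this assay, at which 1 of the 2 values shown sits, behind it, no change clearly beyond the scatter is expected in this assay, only a small rise, estimated as a 1.3-fold higher number from compound 2 to compound 3 (0.13 log units; within the scatter) in size. For compound 3 the estimated value is 80000 nM with an expected range from 40000 nM to 150000 nM in this read-out.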

Compound 3, half-maximal inhibitory concentration: 70200 nM
Compound 3: middle estimate off by 1.1-fold (0.06 log units), on the high side; low and high end bracket the measured number.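

At this position, para to a large group, chloro and fluoro cannot be told apart in this assay: the exchange gives a 1.2-fold higher number from compound 2 to compound 3 (0.07 log units; within the scatter). Fluoro in place of hydrogen gives an at least 1.4-fold lower number from compound 1 to compound 3 (0.15 log units; that floor lies within the scatter), which is a floor and not a size. That size stays unread because compound 1 reports only a limit: the limit of > 100000 nM in this assay, at which 1 of the 3 values shown sits.

The compounds shown leave open whether a methoxy group or an amine at this position would move the number clearly beyond the scatter.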